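Permeability of Benzimidazole Ether Acids with Pyridinyl Substituents

A few compounds are considered here, and "the series" means these few. Any claim that something is new, unique, unknown or untested is made for them only; others in the source may bear on it.

Measured compounds:
compound 1 `Cc1cccnc1Oc1ccc2nc(COc3cccc(C(=O)O)c3)n(C)c2c1` with 6 10^-6 cm/s
compound 2 `Cn1c(COc2cccc(C(=O)O)c2)nc2ccc(Oc3ncccc3F)cc21` with 3.9 10^-6 cm/s
compound 3 `Cn1c(COc2cccc(C(=O)O)c2)nc2ccc(Oc3ncc(Cl)cc3F)cc21` with 11.8 10^-6 cm/s

In an ADME assay for permeability, using PAMPA, with a stated time of 4 h (a lower number here means that the compound crosses the layer more slowly, a higher number that the compound crosses the layer faster), compound 2 gives 3.9 10^-6 cm/s, compound 1 gives 6 10^-6 cm/s and compound 3 gives 11.8 10^-6 cm/s. The change methyl in place of fluoro on an aromatic carbon produced a 1.5-fold higher number from compound 2 to compound 1 (0.19 log units; within the scatter). Compound 1 to compound 3 gave a 2.0-fold higher number from compound 1 to compound 3 (0.29 log units; within the scatter), and compound 2 to compound 3 gave a 3.0-fold higher number from compound 2 to compound 3 (0.48 log units; beyond the scatter).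

Compound 4 `Cc1cc(Cl)cnc1Oc1ccc2nc(COc3cccc(C(=O)O)c3)n(C)c2c1` has not yet been measured in this assay. It differs from compound 3 by methyl in place of fluoro on an aromatic carbon. The cores of compound 2 and compound 3 differ by chloro in place of hydrogen on an aromatic carbon. In compound 4 the place of the change is meta to a chloro group, which is not so in compound 1, so this is the same kind of change, not the same change. As the earlier step was a 1.5-fold higher number from compound 2 to compound 1 (0.19 log units; within the scatter), a similar step of a 1.3-fold higher number from compound 3 to compound 4 (0.10 log units; within the scatter) is expected, because compound 3 stands at 11.8 10^-6 cm/s. Compound 4 is therefore estimated at 15 10^-6 cm/s, between 7.5 10^-6 cm/s and 30 10^-6 cm/s.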

Compound 4, apparent permeability: 13.7 10^-6 cm/s
Beside the measured number, compound 4's estimate is 1.1-fold (0.04 log units) above it, within the range that was stated.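

With methyl in place of fluoro, this assay gave a 1.2-fold higher number from compound 3 to compound 4 (0.06 log units; within the scatter), and this change carried across the two cores: the same change on two cores in this assay, a 1.5-fold higher number (0.19 log units; within the scatter) from compound 2 to compound 1 and a 1.2-fold higher number (0.06 log units; within the scatter) from compound 3 to compound 4, 1.3-fold (0.12 log units) apart, within the scatter of two such steps. Chloro in place of hydrogen gave a 2.3-fold higher number from compound 1 to compound 4 (0.36 log units; beyond the scatter), the exchange of the whole group gave a 3.5-fold higher number from compound 2 to compound 4 (0.55 log units; beyond the scatter), and the chloro change also carried across: the same change on two cores in this assay, a 3.0-fold higher number (0.48 log units; beyond the scatter) from compound 2 to compound 3 and a 2.3-fold higher number (0.36 log units; beyond the scatter) from compound 1 to compound 4, 1.3-fold (0.12 log units) apart, within the scatter of two such steps. This shows that both changes behaved alike on these two pairs of cores, but it rests on only four compounds, and it does not show that either change would carry to a different core.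

The compounds shown leave open how a nitrile or a methoxy group would compare with methyl and fluoro on that aromatic carbon. They also leave open whether an amine would follow the same pattern.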